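Ethoxy for dimethylamino on the pyrimidinyl piperazine of compound 1

The source may report more compounds than this note shows. Statements on the series, on what has been measured and on what is new or still open speak of the compounds shown alone.

Measured compounds:
compound 1 `COc1cc2nc(N3CCN(c4nccc(N(C)C)n4)CC3)cc(N)c2cc1OC`, 0.46 nM
compound 2 `CCCNC(=O)N1CCN(c2cc(N)c3cc(OC)c(OC)cc3n2)CC1`, 0.44 nM
compound 3 `C=CCNC(=O)N1CCN(c2cc(N)c3cc(OC)c(OC)cc3n2)CC1`, 0.29 nM

All three numbers come from an assay on brain for displacement of a labelled ligand from Adrenergic receptor alpha-1 (Rattus norvegicus) (on this read-out lower numbers stand for stronger inhibition and higher numbers for weaker inhibition), and lie within the scatter of one another. Compound 1 is not separated from compound 2 a 1.0-fold lower number from compound 1 to compound 2 (0.02 log units; within the scatter), nor from compound 3 a 1.6-fold lower number from compound 1 to compound 3 (0.20 log units; within the scatter), and compound 2 to compound 3 is likewise flat a 1.5-fold lower number from compound 2 to compound 3 (0.18 log units; within the scatter). Each of these steps either replaces the whole 4-(dimethylamino)pyrimidin-2-yl group on the piperazine or alters the chain beyond the amide-type nitrogen; none of them alters the pyrimidine itself.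

Compound 4 `CCOc1ccnc(N2CCN(c3cc(N)c4cc(OC)c(OC)cc4n3)CC2)n1` differs from compound 1 in one place: ethoxy in place of dimethylamino on an aromatic carbon. Among the compounds with values here, no measured step touches this position, so the expectation rests only on the observation that every change so far on this side of the shared core left this assay unmoved. No step beyond the scatter is therefore expected from compound 1 to compound 4, a 1.1-fold higher number from compound 1 to compound 4 (0.04 log units; within the scatter). Compound 4 is estimated at 0.5 nM, with a range of 0.2 nM to 1.3 nM.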

Compound 4, inhibition constant: 0.42 nM
Compound 4: middle estimate off by 1.2-fold (0.08 log units), on the high side; measured number inside the range.
By their numbers in this assay, from the lowest: compounds 3, 4, 2 and 1 (each within the scatter of the next).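

In this assay, within the data shown here, this is the first direct reading at this aromatic carbon of the pyrimidine: ethoxy in place of dimethylamino, with the same heavy-atom count and oxygen entering where nitrogen leaves, does not separate the pair (a 1.1-fold lower number from compound 1 to compound 4 (0.04 log units; within the scatter)). The 4-ethoxypyrimidin-2-yl group also stands level with both carbamoyl groups on the amine nitrogen in the ring (a 1.4-fold higher number from compound 3 to compound 4 (0.16 log units; within the scatter); a 1.0-fold lower number from compound 2 to compound 4 (0.02 log units; within the scatter)). No measurement available here explains this flat result.

Both groups compared at this carbon have the same heavy-atom count, so the compounds shown do not tell whether a longer alkoxy chain, such as butoxy, would also leave this assay unmoved. From the compounds shown here alone, a carboxylic acid or a primary amine at the same carbon also remains open.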